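Para-substituent swap on the anilino ring of compound 2

The source may report more compounds than this note shows. Statements on the series, on what has been measured and on what is new or still open speak of the compounds shown alone.

Compound 1 `O=C1C=C(N2CCC2)C(=O)c2c1nc1n2[C@H]2OC[C@@H](O)[C@H]2OC1` carries azetidin-1-yl on a double-bonded ring carbon of the shared core. In a functional assay on ECa-109 cells for inhibition, with ECa-109 cell line (Homo sapiens) as the target, read by sulforhodamine B assay (a higher number here means a weaker inhibitor, a lower number a stronger inhibitor), compound 1 reaches only a limit of the assay, > 16000 nM. Compound 2 `COc1ccc(NC2=CC(=O)c3nc4n(c3C2=O)[C@H]2OC[C@@H](O)[C@H]2OC4)cc1` bears (4-methoxyphenyl)amino at the same place. In this assay compound 2 likewise gives only a limit, > 4000 nM. The step that the two limits leave unreadable from compound 1 to compound 2 cannot be sized, since both ends sit at limits (the limit of > 16000 nM in this assay, at which 1 of the 2 values shown sits, (the limit of > 4000 nM in this assay, at which 1 of the 2 values shown sits)). Compound 2 therefore stands nowhere definite on the numbers: it is merely no stronger than its limit allows.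

Compound 3 `O=C1C=C(Nc2ccc(I)cc2)C(=O)c2c1nc1n2[C@H]2OC[C@@H](O)[C@H]2OC1` differs from compound 2 by iodo in place of methoxy on an aromatic carbon. Within the data shown here, no measured step bears on this change; the one step is unreadable. The step that the limit leaves unreadable from compound 2 to compound 3 is thus expected to be small or absent, with compound 3 most likely remaining at or near a limit. Compound 3 is estimated at 8000 nM, within 2000 nM to 30000 nM.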

Compound 3, half-maximal inhibitory concentration: 2300 nM
The estimate for compound 3 lay 3.5-fold (0.54 log units) above the measured number; low and high end bracket the measured number.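

Replacing azetidin-1-yl with (4-iodophenyl)amino on the double-bonded ring carbon gives an at least 6.9-fold lower number from compound 1 to compound 3 (0.84 log units; beyond the scatter), so the group at this position can change the read-out in this assay by more than the usual scatter. Compound 3 is also the only compound shown with a number rather than a limit, which gives the series its first fixed reference point. For iodo in place of methoxy on the aromatic carbon, the record gives an at least 1.7-fold lower number from compound 2 to compound 3 (0.24 log units; that floor lies within the scatter), so this smaller change is not yet shown to matter, as the limit for compound 2 leaves its true number unknown.

As far as these compounds go, the real size of the gap between compound 2 and compound 3 stays open. Also open, from the compounds shown here alone, is how bromo, chloro, an amine or a carboxylic acid on that same aromatic carbon would read in this assay.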